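A Bromo-to-Hydrogen Change Starting from an Assay Limit

This account rests on a few compounds, and the source may have more. Where it says the series, first, only, none or still open, it means among the compounds named here.

Compound 1 `O=C(Nc1ccc(F)cc1)N1N=C(c2ccc(Br)cc2)CC1c1ccc(F)cc1` — > 10000 nM
Compound 2 `COc1ccc(NC(=O)N2N=C(c3ccc(Br)cc3)CC2c2ccc(F)cc2)cc1` — > 10000 nM
Compound 3 `O=C(Nc1ccccn1)N1N=C(c2ccc(Br)cc2)CC1c1ccc(F)cc1` — 2180 nM

In an assay on HEK293 cells for inhibition of Voltage-dependent L-type calcium channel subunit alpha-1C (Homo sapiens), read by FLIPR and calcium flux, with a stated time of 3 min (on this read-out lower numbers stand for stronger inhibition and higher numbers for weaker inhibition), compound 1 gives > 10000 nM, which is a limit of the assay and not a number. Compound 2 likewise reaches only a limit, > 10000 nM. Compound 3 gives 2180 nM. Compound 1 thus stands at the limit at which two of the three values shown sit (the limit of > 10000 nM in this assay, at which 2 of the 3 values shown sit). The step that the two limits leave unreadable from compound 1 to compound 2 stays unreadable between two limits, while the steps of an at least 4.5-fold lower number from compound 1 to compound 3 (0.66 log units; beyond the scatter) and an at least 4.5-fold lower number from compound 2 to compound 3 (0.66 log units; beyond the scatter) are at least modest and point to lower numbers. Compound 4 `O=C(Nc1ccc(F)cc1)N1N=C(c2ccccc2)CC1c1ccc(F)cc1` differs from compound 1 in hydrogen in place of bromo on an aromatic carbon, a change at the 4-bromophenyl group. Going by the values given here, none of the measured steps concerns that group, so no measured step bears directly on this change. With compound 1 at the limit, compound 4 is expected to remain near it, and the step that the limit leaves unreadable from compound 1 to compound 4 is expected to be none beyond the scatter. Compound 4 is estimated at 15000 nM, within a range from 5000 nM to 50000 nM.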

Compound 4, half-maximal inhibitory concentration in the Voltage-dependent L-type calcium channel subunit alpha-1C assay: > 10000 nM
Compound 4: a limit, no number; the forecaster's own chance of this, stated with the estimate: 80%; the middle value is on the limit's open side.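

In the Voltage-dependent L-type calcium channel subunit alpha-1C assay compound 4 gives > 10000 nM, a limit of the assay and not a number. In a physicochemical assay for solubility, read by HPLC, at pH 4 (a lower number here means a less soluble compound, a higher number a more soluble compound), compound 1 gives < 1 ug/mL, a limit of the assay and not a number. In the physicochemical assay compound 4 gives < 1 ug/mL, again a limit of the assay and not a number. Going by these compounds alone, compound 1 also stands at a limit in the Voltage-dependent L-type calcium channel subunit alpha-1C assay, so no step between compound 1 and compound 4 can be read in the Voltage-dependent L-type calcium channel subunit alpha-1C assay or in the physicochemical assay. The compounds shown leave open whether hydrogen in place of bromo changes either read-out at all.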